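Replacing a Pyrrolidine with a Methylpiperazine on the Amide Arm

The source may report more compounds than this note shows. Statements on the series, on what has been measured and on what is new or still open speak of the compounds shown alone.

Measured so far in a functional assay on MCF7 cells (Homo sapiens) for antiproliferative activity, read by MTT assay, with a stated time of 48 h; a higher number here means a weaker inhibitor, a lower number a stronger inhibitor:
compound 1 `COc1ccc(-c2cc3cc(OC)ccc3nc2Nc2ccc(NC(=O)CN(C)C)cc2)cc1` gives 39500 nM
compound 2 `COc1ccc(-c2cc3cc(OC)ccc3nc2Nc2ccc(NC(=O)CN3CCCC3)cc2)cc1` gives 7290 nM

Compound 2 stands lowest of the two numbers shown; its nearest neighbour is compound 1, and the only measured step, a 5.4-fold lower number from compound 1 to compound 2 (0.73 log units; beyond the scatter), lies beyond the scatter. That step exchanged a small open-chain amine for a ring amine at the same place.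

Compound 3 `COc1ccc(-c2cc3cc(OC)ccc3nc2Nc2ccc(NC(=O)CN3CCN(C)CC3)cc2)cc1` is not yet measured. It differs from compound 2 by 4-methylpiperazin-1-yl in place of pyrrolidin-1-yl on a saturated chain carbon bound to a carbonyl carbon, again at the end of the same amide arm.

Among the measured compounds shown here, only the step from compound 1 to compound 2 bears on this, and it is indirect: it shows that the amine at this position matters, but it does not show how a six-membered ring with two nitrogen atoms compares with a five-membered ring with one. For the measured compounds named here, no measured step covers that exchange, so no direction can be read from the data. The expected step is therefore a 1.4-fold higher number from compound 2 to compound 3 (0.14 log units; within the scatter), around no change beyond the scatter. Compound 3 is estimated at 10000 nM, with a range from 3000 nM to 35000 nM.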

Compound 3, half-maximal inhibitory concentration: 1800 nM
Compound 3: middle estimate off by 5.6-fold (0.74 log units), on the high side; the whole stated range lies above it.
By their numbers in this assay, from the lowest: compound 3; then compound 2; then compound 1.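

In this assay, the amine at the end of the amide arm still had room to improve after the first ring was introduced: the six-membered ring gives a further drop (a 4.1-fold lower number from compound 2 to compound 3 (0.61 log units; beyond the scatter)), and the total change from the open-chain amine is large (a 22-fold lower number from compound 1 to compound 3 (1.34 log units; beyond the scatter)). The earlier step could have been read as a simple difference between open-chain and ring amines, but the two ring amines here also differ beyond the scatter, so the identity of the ring matters on this saturated chain carbon bound to a carbonyl carbon. Nothing available explains why this exchange lowers the number.

The exchange changes the ring size, adds a second ring nitrogen and brings in a methyl group all at once, so the compounds shown cannot say which of these changes accounts for the step. Piperidin-1-yl, a six-membered ring with one nitrogen, and piperazin-1-yl, which lacks the methyl group, would each separate part of that change, while morpholin-4-yl would show what happens with an oxygen in place of the second nitrogen.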